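Fluoro on the pendant phenyl of compound 1

The source may report more compounds than this note shows. Statements on the series, on what has been measured and on what is new or still open speak of the compounds shown alone.

Among the compounds with values here, compound 1 `c1ccc(-c2cn3ccnc3c(-c3ccc4ncn(C5CCCCC5)c4c3)n2)cc1` is one of three compounds measured in a functional assay on LOX IMVI cells (Homo sapiens) for inhibition, read by sulforhodamine B assay, with a stated time of 48 h, tested at 10 uM; a lower number here means less inhibition, a higher number more inhibition at the concentration tested (going by the name of the read-out). There compound 1 gives 39.6%, which is the second highest of the three numbers. Compound 2 `COc1ccc(-c2cn3ccnc3c(-c3ccc4ncn(C5CCCCC5)c4c3)n2)cc1`, carrying methoxy in place of hydrogen on an aromatic carbon, gives 69.6%, and the step of a number 30 percentage points higher from compound 1 to compound 2 (beyond the scatter) lies beyond the scatter. Compound 3 `c1ccc2c(-c3cn4ccnc4c(-c4ccc5ncn(C6CCCCC6)c5c4)n3)cccc2c1`, with naphthalen-1-yl in place of phenyl on an aromatic carbon, gives 7.43%; the step of a number 32.2 percentage points lower from compound 1 to compound 3 (beyond the scatter) is large, as is a number 62.2 percentage points lower from compound 2 to compound 3 (beyond the scatter).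

Compound 4 `Fc1ccccc1-c1cn2ccnc2c(-c2ccc3ncn(C4CCCCC4)c3c2)n1` has not been measured. Relative to compound 1 the change is fluoro in place of hydrogen on an aromatic carbon, entering ortho to a large group. Within the data shown here, no measured step adds a single small group at that place: the methoxy of compound 2 sits elsewhere, and compound 3 adds a whole fused ring. The closest comparison is therefore weak; the drop to compound 3 suggests additions on that side of the phenyl do not raise the read-out, while a single fluorine is far smaller. A step about the size of the scatter, in either direction, is expected, a number 2.6 percentage points lower from compound 1 to compound 4 (within the scatter). Compound 4 is estimated at 37%, within 18% to 58%.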

Compound 4, a percentage reported as inhibition, at one concentration (the size of the read-out at that concentration, not a potency): 5.77%
Estimate against measurement, compound 4: 31.2 percentage points above, outside the stated range (below it).
By their numbers in this assay, from the lowest: compounds 4 and 3 (each within the scatter of the next); then compound 1; then compound 2.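

In this assay, one fluoro ortho to a large group is enough for a number 33.8 percentage points lower from compound 1 to compound 4 (beyond the scatter), so this place on the phenyl responds strongly to the smallest substitution shown. The single atom leaves the read-out level with that of the naphthalen-1-yl compound, a number 1.7 percentage points lower from compound 3 to compound 4 (within the scatter), and well away from the 4-methoxyphenyl compound, a number 63.8 percentage points lower from compound 2 to compound 4 (beyond the scatter), so a large drop here does not need a whole fused ring. No supporting data accompany these numbers to explain the drop.

On these data alone, whether the drop belongs to fluoro itself or to any group at this place remains open, and a chloro, methyl or amine there would address that. A fluoro at the place held by the methoxy of compound 2 would show whether the drop depends on position.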